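From 2,4-Difluorophenyl to 4-Acetylphenyl on a Shared Core

The source may report more compounds than this note shows. Statements on the series, on what has been measured and on what is new or still open speak of the compounds shown alone.

Compound 1 `Nc1nc(N)c2cc(CSC(=S)N3CCN(c4ccccc4)CC3)ccc2n1`: 2840 nM
Compound 2 `Nc1nc(N)c2cc(CSC(=S)N3CCN(c4ccc(F)cc4F)CC3)ccc2n1`: 3800 nM

Both values come from a functional assay on HeLa cells (Homo sapiens) for antiproliferative activity, read by MTT assay, with a stated time of 72 h; a higher number here means a weaker inhibitor, a lower number a stronger inhibitor. Only these two compounds have been measured in this series, and their values lie within the scatter of each other, so compound 2 cannot be ranked apart from compound 1.

The next compound to consider is compound 3 `CC(=O)c1ccc(N2CCN(C(=S)SCc3ccc4nc(N)nc(N)c4c3)CC2)cc1`, which has 4-acetylphenyl in place of the 2,4-difluorophenyl of compound 2 on an amine nitrogen in a ring: 4-acetylphenyl in place of 2,4-difluorophenyl on an amine nitrogen in a ring. Within the data shown here, one measured step bears on this change, as it involves a substituent on the same nitrogen: a 1.3-fold higher number from compound 1 to compound 2 (0.13 log units; within the scatter). That step did not exceed the scatter. Among the measured compounds shown here, it is the only guide, and no measured compound carries an acetyl group, so the forecast remains loose. No shift beyond the scatter is expected in this assay, and no direction can be favoured. The expected step is a 1.2-fold lower number from compound 2 to compound 3 (0.07 log units; within the scatter). The estimate for compound 3 is 3200 nM, with an expected range from 1200 nM to 8500 nM.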

Compound 3, half-maximal inhibitory concentration: 2040 nM
For compound 3 the middle estimate is 1.6-fold (0.20 log units) above the measured one, within the range that was stated.
By their numbers in this assay, from the lowest: compounds 3, 1 and 2 (each within the scatter of the next).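

The acetyl result extends what was known about the aryl group on the ring nitrogen in this assay: until now only phenyl and 2,4-difluorophenyl had been compared there, and neither group carries a hydrogen-bond acceptor, whereas 4-acetylphenyl carries one and also a double bond outside the aromatic ring. Even so, exchanging 2,4-difluorophenyl for 4-acetylphenyl gives a 1.9-fold lower number from compound 2 to compound 3 (0.27 log units; within the scatter), and placing acetyl on the phenyl ring of compound 1 gives a 1.4-fold lower number from compound 1 to compound 3 (0.14 log units; within the scatter), so all three aryl groups remain indistinguishable in this assay and none can be ranked above another, despite the added acceptor and the larger group. No independent measurement is available here to account for these numbers.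

What the compounds shown leave open is whether a group of another kind on the phenyl ring, such as an amine or a carboxylic acid, would move the number beyond the scatter. They also leave open whether anything other than an aryl group on this nitrogen, such as a longer alkyl chain, would keep the values in the same range, since every compound here carries a six-membered aromatic ring at this place.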